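The source may report more compounds than this note shows. Statements on the series, on what has been measured and on what is new or still open speak of the compounds shown alone.

In an ADME assay on Vero cells (Chlorocebus sabaeus) for cytotoxicity, read by MTT assay, with a stated time of 96 h (a higher number here means that more compound is tolerated, a lower number that less compound is tolerated), compound 3 (`COc1ccc(-c2nc3cc(/C(C)=N/NC(N)=S)ccc3[nH]2)c(OC)c1`) gives > 100000 nM as a limit and not a number. Compound 1 (`COc1ccc(-c2nc3cc(/C(C)=N/O)ccc3[nH]2)c(OC)c1`) gives > 100000 nM as a limit too. Compound 2 (`COc1ccc(-c2nc3cc(/C(C)=N/NC(N)=S)ccc3[nH]2)cc1`) also gives > 100000 nM as a limit. The measured series therefore rests on the limit of > 100000 nM in this assay, at which 3 of the 3 values shown sit, and holds no readable number. Compound 4 (`COc1ccc(-c2nc3cc(/C(C)=N/NC(N)=S)ccc3n2C2CCCCC2)c(OC)c1`) follows from cyclohexyl in place of hydrogen on an aromatic nitrogen on the shared core. Within the data shown here, two measured steps bear on it: a step that the two limits leave unreadable from compound 1 to compound 3 and a step that the two limits leave unreadable from compound 2 to compound 3 give no size to carry over, and neither involves the aromatic nitrogen. Compound 3 holds > 100000 nM as its limit, so a readable step could only run toward less compound tolerated, and a moderate one is expected. The estimated move is an at least 1.6-fold lower number from compound 3 to compound 4 (0.22 log units; that floor lies within the scatter) in that direction. For compound 4 the expected value is 60000 nM with an estimated range from 15000 nM to 100000 nM in this assay as the working figure.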

Compound 4, half-maximal cytotoxic concentration: 20000 nM
Compound 4: the middle estimate sits 3.0-fold (0.48 log units) above what was measured, and the stated range covers the measured number.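

Cyclohexyl in place of hydrogen on the aromatic nitrogen gives, in this assay, an at least 5.0-fold lower number from compound 3 to compound 4 (0.69 log units; beyond the scatter), making this the first position in the series where a change yields a readable step. The earlier steps cannot be read, and the series otherwise rests on a limit: the limit of > 100000 nM in this assay, at which 3 of the 4 values shown sit.

The compounds shown leave open whether methyl, a longer carbon chain or a chain bearing an amine on this nitrogen would give a step of similar size. From the compounds shown here alone, whether cyclohexyl on this nitrogen would also lower the number on the core of compound 1 stays open too.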